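Tert-butyl in place of hydrogen on the benzyl ring

The source may hold more compounds than are shown below. What is called first, only, known or untested is meant among the compounds shown, and "the series" means these compounds.

Compound 1 `CC(=O)OC[C@H]1O[C@@H](n2cc(-c3cn(Cc4ccc(C(C)C)cc4)nn3)c(=O)[nH]c2=O)C[C@@H]1OC(C)=O` and compound 2 `CC(=O)OC[C@H]1O[C@@H](n2cc(-c3cn(Cc4ccccc4)nn3)c(=O)[nH]c2=O)C[C@@H]1OC(C)=O` share one core and differ only at the benzyl ring. In a functional assay on PC-3 cells (Homo sapiens) for cytotoxicity, read by sulforhodamine B assay, tested at 10 uM (a lower number here means less inhibition, a higher number more inhibition at the concentration tested (going by the name of the read-out)), compound 1 gives 91.3%. In the same assay compound 2 gives 92.1%, and the move a number 0.8 percentage points higher from compound 1 to compound 2 (within the scatter) stays within the scatter. Compound 3 `CC(C)(C)c1ccc(Cn2cc(-c3cn([C@H]4C[C@H](O)[C@@H](CO)O4)c(=O)[nH]c3=O)nn2)cc1`, which carries a tert-butyl group on its benzyl ring but sits on a differently decorated core, gives 92.3% in this assay. Among the three numbers, compound 2 stands second highest, within the scatter of both compound 3 and compound 1, so no order among them can be claimed.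

Compound 4 `CC(=O)OC[C@H]1O[C@@H](n2cc(-c3cn(Cc4ccc(C(C)(C)C)cc4)nn3)c(=O)[nH]c2=O)C[C@@H]1OC(C)=O` is compound 2 with one change: tert-butyl in place of hydrogen on an aromatic carbon. Within the data shown here, the only measured step that bears on this change is the one between compound 1 and compound 2, where removing an isopropyl group from the same aromatic carbon moved the number by less than the scatter. The values of compound 3 and compound 2 likewise show nothing beyond the scatter between a tert-butyl group and none, though their cores differ.

For compound 4 a step of a number 0.1 percentage points lower from compound 2 to compound 4 (within the scatter) is therefore expected, nothing beyond the scatter. Compound 4 is estimated at 92% in this assay, between 84% and 97%.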

Compound 4, a percentage reported as inhibition, at one concentration (the size of the read-out at that concentration, not a potency): 90.4%
Compound 4: the middle estimate sits 1.6 percentage points above what was measured; measured number inside the range.
By their numbers in this assay, from the lowest: compounds 4, 1, 2 and 3 (each within the scatter of the next).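

In this assay tert-butyl in place of hydrogen on the benzyl ring gives a number 1.7 percentage points lower from compound 2 to compound 4 (within the scatter) on the shared core, so this aromatic carbon carries the larger group as well as it carried isopropyl, with no change that can be told from the scatter. Comparing the two branched groups directly gives a number 0.9 percentage points lower from compound 1 to compound 4 (within the scatter), so the one extra methyl that turns isopropyl into tert-butyl cannot be seen in this read-out either. Nothing measured here gives any explanation for why these numbers stay so close together.

All of these compounds were read at one concentration and lie within the scatter of their neighbours, so the numbers do not rank them and say nothing about potency, which would need tests at lower concentrations, where differences hidden here might appear. Going by these compounds, what an amine, a carboxylic acid or a longer chain would do to the number on the same ring carbon remains open, and so does whether the number stays level with any group on the benzyl ring that is not a plain hydrocarbon group.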